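The compounds below may be only part of what the source reports. "The series", "measured", "known", "first", "only" and "open" are said of these compounds alone.

Measured compounds in a functional assay on A549 cells (Homo sapiens) for cytotoxicity, read by MTT assay, with a stated time of 48 h; on this read-out higher numbers stand for weaker inhibition and lower numbers for stronger inhibition:
compound 1 `COc1ccc(C(=O)/C=C/c2ccc(OCc3cn(Cc4ccccc4)nn3)cc2)cc1` gives 11000 nM
compound 2 `COc1ccc(C(=O)/C=C/c2ccc(OCc3cn(Cc4ccccc4Br)nn3)cc2)cc1` gives 10000 nM
compound 3 `COc1ccc(C(=O)/C=C/c2ccc(OCc3cn(Cc4ccc(Br)cc4)nn3)cc2)cc1` gives 10000 nM

Compound 3 sits level with compound 2 at the digits shown, the two together giving the lowest numbers of the three; its nearest neighbour is compound 2, with no change at the digits printed from compound 2 to compound 3 (within the scatter), and its furthest is compound 1, the gap to which is within the scatter. None of the three compounds can be ranked against the others.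

The next compound, compound 4 `COc1ccc(C(=O)/C=C/c2ccc(OCc3cn(Cc4cccc(F)c4)nn3)cc2)cc1`, is to be measured in this assay. It differs from compound 3 in one place: 3-fluorophenyl in place of 4-bromophenyl on a saturated chain carbon bound to an aromatic nitrogen.

Steps that bear on this change are those that swap the aryl group on the saturated chain carbon bound to the aromatic nitrogen. Adding bromo to the ring gave a 1.1-fold lower number from compound 1 to compound 2 (0.04 log units; within the scatter) and a 1.1-fold lower number from compound 1 to compound 3 (0.04 log units; within the scatter); moving the bromo from one ring position to the other gave no change at the digits printed from compound 2 to compound 3 (within the scatter). Among the compounds with values here, all of these lie within the scatter, so the series so far shows no sensitivity to substitution on this ring. A fluoro in place of bromo is a change of the same kind, and a step of a 1.1-fold higher number from compound 3 to compound 4 (0.02 log units; within the scatter) is expected, that is none beyond the scatter.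

Compound 4 is therefore estimated at 10500 nM, with a range of 5000 nM to 22000 nM.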

Compound 4, half-maximal inhibitory concentration: 9000 nM
For compound 4 the middle estimate is 1.2-fold (0.07 log units) above the measured one, and the stated range covers the measured number.
By their numbers in this assay, from the lowest: compounds 4, 2, 3 and 1 (each within the scatter of the next).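

In this assay the first halogen other than bromo on this ring gives a 1.1-fold lower number from compound 3 to compound 4 (0.05 log units; within the scatter), and set against the other bromo isomer it gives a 1.1-fold lower number from compound 2 to compound 4 (0.05 log units; within the scatter), so exchanging either bromobenzyl group for 3-fluorobenzyl leaves the read-out within the scatter, a point the bromo compounds alone could not settle. Against the unsubstituted benzyl compound, fluoro in place of hydrogen gives a 1.2-fold lower number from compound 1 to compound 4 (0.09 log units; within the scatter), which extends the flat picture at this position from bromo to fluoro across the four compounds, with none going against it. No measurement beyond these cell numbers is available to interpret this flat result.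

All four compounds carry only hydrogen or a single halogen on the benzyl ring, which leaves open whether a group of another kind there, such as an amine or a carboxylic acid, or a longer chain in place of the benzyl group, would move the number beyond the scatter. Also open, going by these compounds, is whether a change in the shared core, for instance a hydroxyl in place of its methoxy group, would shift the read-out in a way that substitution on this ring has not.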